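Trifluoromethyl for Fluoro on the Benzyl Ring

A few compounds are considered here, and "the series" means these few. Any claim that something is new, unique, unknown or untested is made for them only; others in the source may bear on it.

In a functional assay on CCRF-CEM cells (Homo sapiens) for cytotoxicity, read by cell counting, with a stated time of 3 days (on this read-out higher numbers stand for weaker inhibition and lower numbers for stronger inhibition), compound 1 `Nc1cccc(/C=C2\SC(=O)N(Cc3ccc(F)cc3)C2=O)c1` gives 87000 nM, the lowest of the three numbers measured. Compound 3 `Nc1ccc(/C=C2\SC(=O)N(Cc3ccc(F)cc3)C2=O)cc1` gives 111000 nM, and compound 2 `Nc1cccc(/C=C2\SC(=O)N(Cc3cccc(Cl)c3)C2=O)c1` gives 195000 nM. The step of a 1.3-fold higher number from compound 1 to compound 3 (0.11 log units; within the scatter) lies within the scatter, while a 2.2-fold higher number from compound 1 to compound 2 (0.35 log units; beyond the scatter) goes beyond it. Compound 4 `Nc1cccc(/C=C2\SC(=O)N(Cc3ccc(C(F)(F)F)cc3)C2=O)c1` differs from compound 1 by trifluoromethyl in place of fluoro on an aromatic carbon. Within the data shown here, only the step from compound 1 to compound 2 changes the same part of the molecule, and it was modest; no measured step swaps fluoro for trifluoromethyl. A small rise or no change beyond the scatter is therefore expected for compound 4, a 1.4-fold higher number from compound 1 to compound 4 (0.14 log units; within the scatter). Compound 4 is estimated at 120000 nM, with a range from 50000 nM to 300000 nM.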

Compound 4, half-maximal inhibitory concentration: > 250000 nM
Compound 4 was reported as a limit; the forecaster's own chance of this, stated with the estimate: 10%; middle value at least 2.0-fold (0.31 log units) away from the limit.
By their numbers in this assay, from the lowest: compounds 1, 3 and 2 (each within the scatter of the next, the first and the last beyond it). At a limit, above all of these: compound 4.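

With only the group changing on this aromatic carbon, para to a large group, trifluoromethyl in place of fluoro gives an at least 2.8-fold higher number from compound 1 to compound 4 (0.45 log units; beyond the scatter) in this assay. Among these compounds, the earlier step on this ring, a 2.2-fold higher number from compound 1 to compound 2 (0.35 log units; beyond the scatter), changed group and place together, so this is the first reading of a group change alone. The value of compound 4 is a limit: the limit of > 250000 nM in this assay, at which 1 of the 4 values shown sits.

Still open, on these data alone, is how a methoxy group or an amine on this carbon would compare with fluoro. Also open, as far as these compounds go, is whether trifluoromethyl gives a similar step on the 4-aminophenyl compound 3.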